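Pyrazole-fused pyran nitriles: methyl to phenyl at ring carbon

A few compounds are considered here, and "the series" means these few. Any claim that something is new, unique, unknown or untested is made for them only; others in the source may bear on it.

Measured in a functional assay on NCI-H2122 cells (Homo sapiens) for inhibition, read by microscopy, with a stated time of 10 days; on this read-out lower numbers stand for stronger inhibition and higher numbers for weaker inhibition:
compound 1 `Cn1nc(-c2ccccc2)c2c1OC(N)=C(C#N)C2c1ccccc1` — > 10000 nM, a limit of the assay
compound 2 `COc1ccc(-c2nn(C)c3c2C(c2ccc(F)cc2)C(C#N)=C(N)O3)cc1OC` — > 10000 nM, a limit of the assay
compound 3 `COc1ccc(C2C(C#N)=C(N)Oc3c2c(C)nn3-c2ccccc2)cc1` — 4100 nM

Among the measured compounds shown here, compound 3 is the only member of the set with a number in this assay. The other two values are limits: compound 1 reaches only (the limit of > 10000 nM in this assay, at which 2 of the 3 values shown sit), and the same holds for compound 2. For the measured compounds named here, compound 3 therefore stands as the single reference point, and no step between two numbers can be read.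

Compound 4 `COc1ccc(C2C(C#N)=C(N)Oc3c2c(-c2ccccc2)nn3-c2ccccc2)cc1` is not yet measured. It differs from compound 3 in one place: phenyl in place of methyl on an aromatic carbon of the shared core. Compound 1 also carries phenyl at that carbon, together with methyl on the ring nitrogen and no methoxy on either phenyl, and gives only a limit; whether that outcome owes anything to the phenyl cannot be separated from its other differences.

Going by the values given here, with no measured step of this kind, the expectation for compound 4 in this assay is a step from compound 3 that is at most modest, a 1.5-fold higher number from compound 3 to compound 4 (0.17 log units; within the scatter), with a real chance of a limit. The estimate for compound 4 is 6000 nM, within 2000 nM to 20000 nM.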

Compound 4, half-maximal inhibitory concentration: 3100 nM
The estimate for compound 4 lay 1.9-fold (0.29 log units) above the measured number; the range from low to high includes it.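

In this assay, this aromatic carbon now has a measured step: phenyl in place of methyl gives a 1.3-fold lower number from compound 3 to compound 4 (0.12 log units; within the scatter). The shared core of compound 3 and compound 4 therefore carries either methyl or phenyl here with the two values within the scatter of each other, and with phenyl at this carbon compound 4 still gives a number rather than a limit. Compound 1 and compound 2 each differ from compound 4 in more than one place, so no steps involving them can be read, and both stay as limits of the assay: the limit of > 10000 nM in this assay, at which 2 of the 4 values shown sit.

Only methyl and phenyl are shown at this carbon, so it remains open how the read-out responds to a group carrying a different kind of atom, such as an amine, a carboxylic acid or a pyridine ring. On these data alone, the methoxy on the phenyl group and the phenyl on the ring nitrogen, common to compound 3 and compound 4, are not varied alone here, so what each contributes to these values remains unknown.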